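Swapping Isobutyl for sec-Butyl on an Amine Nitrogen

The source may report more compounds than this note shows. Statements on the series, on what has been measured and on what is new or still open speak of the compounds shown alone.

Of the compounds shown here, three have been tested in an ADME assay on Caco-2 cells (Homo sapiens) for inhibition, read by MTT assay, with a stated time of 72 h; on this read-out higher numbers stand for weaker inhibition and lower numbers for stronger inhibition. Compound 3 `COc1cc(/C=C/C(=O)/C=C(/C=C/c2ccc(O)c(OC)c2)NCC(C)C)ccc1O` carries an isobutyl group on its amine nitrogen. In this assay compound 3 gives > 25000 nM, which is a limit of the assay rather than a number. Compound 1 `CCC(C)NC(=C\C(=O)/C=C/c1ccc(O)c(OC)c1)/C=C/c1ccc(O)c(OC)c1` differs from compound 3 by sec-butyl in place of isobutyl on an amine nitrogen. In this assay compound 1 gives > 25000 nM, again a limit rather than a number. The resulting step is a step that the two limits leave unreadable from compound 3 to compound 1. Compound 2 `COc1cc(/C=C/C(=O)/C=C(/C=C/c2ccc(OC(C)=O)c(OC)c2)NCC(C)C)ccc1OC(C)=O` carries the isobutyl group on a different core; the difference between the two cores is not broken down here. In this assay compound 2 gives > 25000 nM, also a limit rather than a number. Compound 4 `CCC(C)NC(=C\C(=O)/C=C/c1ccc(OC(C)=O)c(OC)c1)/C=C/c1ccc(OC(C)=O)c(OC)c1` has not yet been measured and differs from compound 2 by sec-butyl in place of isobutyl on an amine nitrogen, the same change as from compound 3 to compound 1. Because the limit of > 25000 nM in this assay, at which 3 of the 3 values shown sit, holds all three measured values, the change is expected to make a step that the limit leaves unreadable from compound 2 to compound 4. Compound 4 is estimated at 40000 nM, with a likely range from 25000 nM to 100000 nM, and most probably only a limit will be reported.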

Compound 4, half-maximal inhibitory concentration: > 25000 nM
Compound 4 was reported as a limit; the forecaster's own chance of this, stated with the estimate: 85%; the middle value does not contradict the limit.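

Compound 2 and compound 4 differ only by sec-butyl in place of isobutyl, yet no step can be read between them, because both results are limits of the assay and not numbers: the limit of > 25000 nM in this assay, at which 4 of the 4 values shown sit.

The compounds shown leave open how strongly any of them acts in this assay and whether this swap changes that at all.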